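A few compounds are considered here, and "the series" means these few. Any claim that something is new, unique, unknown or untested is made for them only; others in the source may bear on it.

In a functional assay (Cavia porcellus) for antagonist activity at Serotonin 3 (5-HT3) receptor (Homo sapiens) (a higher number here means a weaker inhibitor, a lower number a stronger inhibitor), compound 3 `Cc1[nH]cnc1CN1CCN(c2cccc(Cl)c2)C1=O` gives 12 nM. Compound 1 `Cc1cccc(N2CCN(C3CN4CCC3CC4)C2=O)c1` gives 12 nM in this assay, which leaves compound 3 level with compound 1 at the digits shown; together they hold the lowest of the three numbers. Compound 2 `O=C1N(c2cc(Cl)cc(Cl)c2)CCN1C1CN2CCC1CC2` gives 45 nM in this assay, a higher number that lies beyond the usual scatter and makes compound 2 the furthest of the three from compound 3. Within the data shown here, no pair of measured compounds differs in only one place, so no measured step shows how much a single change of this kind moves the number. Compound 4 `Cc1[nH]cnc1CN1CCN(c2cccc(C(F)(F)F)c2)C1=O` differs from compound 3 in one place: trifluoromethyl in place of chloro on an aromatic carbon. Among the measured compounds shown here, none of the measured compounds carries a trifluoromethyl, so the expectation rests on the closeness of compound 3 to compound 1 and on the modest spread among the three. The step from compound 3 to compound 4 is expected to be small, a 1.7-fold higher number from compound 3 to compound 4 (0.22 log units; within the scatter), with the number rising slightly if at all. Compound 4 is therefore estimated at 20 nM in this assay, within a range from 6 nM to 65 nM.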

Compound 4, antagonist equilibrium constant: 68.5 nM
Estimate against measurement, compound 4: 3.4-fold (0.53 log units) below; the whole stated range lies below it.
By their numbers in this assay, from the lowest: compounds 1 and 3 (each within the scatter of the next); then compounds 2 and 4 (each within the scatter of the next).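

Among these compounds, on the aromatic carbon that carries chloro in compound 3, trifluoromethyl gives the first one-place comparison, and in this assay it produces a 5.7-fold higher number from compound 3 to compound 4 (0.76 log units; beyond the scatter), so this position does not accept the two groups interchangeably. The earlier compounds shown here could not show this, as no two of them differed in only one place and the size of a single change could not be read. Nothing measured here speaks to the reason for this step.

The compounds shown leave open whether the same exchange would move the number similarly on the core shared by compound 1 and compound 2. They also leave open where other groups on this aromatic carbon, such as a nitrile, a methoxy group or an amine, would fall relative to chloro and trifluoromethyl.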